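Swapping methyl for trifluoromethyl at the assay limit

This account rests on a few compounds, and the source may have more. Where it says the series, first, only, none or still open, it means among the compounds named here.

Compound 1 `FC(F)(F)Oc1ccc(/C=C/c2ccc3ccccc3c2)cc1`: > 5000 nM
Compound 2 `Cc1ccc(/C=C\c2ccc3ccccc3c2)cc1`: > 5000 nM

Both compounds were tested in a functional assay on SK-MEL-28 cells (Homo sapiens) for inhibition; on this read-out higher numbers stand for weaker inhibition and lower numbers for stronger inhibition. Compound 2 gives > 5000 nM, which is a limit of the assay and not a number. Compound 1 gives > 5000 nM, which is also a limit. The whole picture so far is the limit of > 5000 nM in this assay, at which 2 of the 2 values shown sit. Compound 2 therefore has no exact value, and no order between the two compounds can be read from these results.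

Compound 3 `FC(F)(F)c1ccc(/C=C\c2ccc3ccccc3c2)cc1` keeps the core of compound 2 and changes one group, with trifluoromethyl in place of methyl on an aromatic carbon. Among the compounds with values here, no measured pair shows what this swap does. The expectation in this assay is a step in neither direction, with none beyond the scatter. That expectation rests on compound 2, whose > 5000 nM is a limit. Another limit is the likeliest report for the new compound. The expected step is a step that the limit leaves unreadable from compound 2 to compound 3. For compound 3 the estimate is 6000 nM, with an expected range of 2000 nM to 15000 nM.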

Compound 3, half-maximal inhibitory concentration: > 5000 nM
Compound 3: no number, only a limit; the forecaster's own chance of this, stated with the estimate: 70%; the middle value does not contradict the limit.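

Compound 3 gives > 5000 nM in this assay, which is a limit of the assay and not a number. Compound 2 also stands at a limit, and no step between compound 2 and compound 3 can be read: the limit of > 5000 nM in this assay, at which 3 of the 3 values shown sit.

As far as these compounds go, what trifluoromethyl in place of methyl on an aromatic carbon does to inhibition stays open, as does any order among the three compounds.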